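This account rests on a few compounds, and the source may have more. Where it says the series, first, only, none or still open, it means among the compounds named here.

Compound 1 `CCC(=O)Nc1c(C(O)(C(F)(F)F)C(F)(F)F)ccc2ccccc12` gives 96% in a functional assay (Sus scrofa) with sulfonylurea receptors; K-ATP channels (Homo sapiens) as the target; a lower number here means a smaller maximal response, a higher number a larger maximal response. Compound 2 `CC(C)=CC(=O)Nc1c(C(O)(C(F)(F)F)C(F)(F)F)ccc2ccccc12` gives 96% in this assay, and compound 3 `COCC(=O)Nc1c(C(O)(C(F)(F)F)C(F)(F)F)ccc2ccccc12` gives 93% in this assay. Among these three numbers compound 3 stands lowest, yet the steps of a number 3 percentage points lower from compound 1 to compound 3 (within the scatter) and a number 3 percentage points lower from compound 2 to compound 3 (within the scatter) lie within the scatter, as does no change at the digits printed from compound 1 to compound 2 (within the scatter). Compound 4 `O=C(Nc1c(C(O)(C(F)(F)F)C(F)(F)F)ccc2ccccc12)c1ccc(Cl)cc1` differs from compound 3 by 4-chlorophenyl in place of methoxymethyl on a carbonyl carbon. Among the measured compounds shown here, none of the measured steps brought a ring to this position; all three steps, each changing the group on the carbonyl carbon, left the maximal response within the scatter. On that basis no change beyond the scatter is expected: no change at the digits printed from compound 3 to compound 4 (within the scatter). Compound 4 is therefore estimated to give 93%, within a range from 80% to 100%, in this assay.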

Compound 4, largest response reached (reported as efficacy), in percent of the reference or control that the assay uses: 99%
Estimate against measurement, compound 4: 6 percentage points below, within the range that was stated.
By their numbers in this assay, from the lowest: compounds 3, 1, 2 and 4 (each within the scatter of the next).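

With 4-chlorophenyl, the first ring on this carbonyl carbon, the steps in this assay read a number 6 percentage points higher from compound 3 to compound 4 (within the scatter) and a number 3 percentage points higher from compound 2 to compound 4 (within the scatter) and a number 3 percentage points higher from compound 1 to compound 4 (within the scatter) as well. Among these four compounds, a six-membered aromatic ring carrying chlorine therefore sits on this carbonyl carbon with the maximal response staying as high as with the three open-chain groups. No measurement here bears on why this result came out as it did. From the compounds shown here alone, what a phenyl without chlorine, a carboxylic acid or an amine-bearing chain would do at this position remains open.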